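The source may report more compounds than this note shows. Statements on the series, on what has been measured and on what is new or still open speak of the compounds shown alone.

Compound 1, with the structure `CCn1nc(-c2cccnc2)c2ccccc2c1=O`, carries pyridin-3-yl on the shared core and an ethyl group on the aromatic nitrogen. In an assay on isolated protein (Oryctolagus cuniculus) with Thromboxane-A synthase (Homo sapiens) as the target, tested at 1 uM (on this read-out lower numbers stand for less inhibition and higher numbers for more inhibition at the one concentration tested (going by the name of the read-out)), compound 1 gives 87%. Compound 2, with the structure `O=c1c2ccccc2c(-c2cccnc2)nn1C1CCCC1`, gives 97% in this assay. Going by the values given here, the only step so far, a number 10 percentage points higher from compound 1 to compound 2 (within the scatter), comes from cyclopentyl in place of ethyl on an aromatic nitrogen and lies within the scatter. On the numbers shown, compound 1 stands lowest of two, with compound 2 nearest; the two values do not order the compounds.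

Compound 3, with the structure `CCn1nc(-n2cncn2)c2ccccc2c1=O`, is not yet measured. Its change from compound 1 is 1H-1,2,4-triazol-1-yl in place of pyridin-3-yl on an aromatic carbon. Among the compounds with values here, no measured step touches this place; the step of a number 10 percentage points higher from compound 1 to compound 2 (within the scatter) alters the group on the aromatic nitrogen and says nothing about pyridin-3-yl. Without a comparable change, the expectation for compound 3 is uncertain and leans toward a lower number, since the pyridin-3-yl group is removed. The estimated step is a number 42 percentage points lower from compound 1 to compound 3 (beyond the scatter). Compound 3 is thus expected to give 45% in this assay, within 10% to 80%.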

Compound 3, a percentage reported as inhibition, at one concentration (the size of the read-out at that concentration, not a potency): 0%
The estimate for compound 3 lay 45 percentage points above the measured number; the whole stated range lies above it.
By their numbers in this assay, from the lowest: compound 3; then compounds 1 and 2 (each within the scatter of the next).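

In this assay, 1H-1,2,4-triazol-1-yl in place of pyridin-3-yl on the aromatic carbon gives a number 87 percentage points lower from compound 1 to compound 3 (beyond the scatter), and compound 3 reads 0% at the one concentration tested. Going by these compounds alone, this shows that the read-out depends strongly on the group at this aromatic carbon, whereas the only earlier step, a number 10 percentage points higher from compound 1 to compound 2 (within the scatter), came from the group on the aromatic nitrogen and gave no ordering of the compounds. The exchange alters ring size, the number of hetero atoms and the number of hydrogen-bond acceptors all at once, and nothing available shows which of these matters for the loss, so the drop stays unexplained.

The compounds shown leave open whether the read-out needs pyridin-3-yl in particular or would also hold with another group at this carbon, such as phenyl, pyridin-4-yl or 1H-imidazol-1-yl. They also leave open whether cyclopentyl on the aromatic nitrogen would change the outcome with 1H-1,2,4-triazol-1-yl on the aromatic carbon, as the two changes appear together in none of these compounds.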